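A few compounds are considered here, and "the series" means these few. Any claim that something is new, unique, unknown or untested is made for them only; others in the source may bear on it.

The measured compounds are compound 1 `Cc1ccc(NC(=O)CCC(=O)OCCCCCCSc2ccc([N+](=O)[O-])c3nonc23)cc1`, which in an assay on isolated protein for inhibition of glutathione S-transferase Mu 2 (Homo sapiens), with a stated time of 10 min (on this read-out higher numbers stand for weaker inhibition and lower numbers for stronger inhibition), gives 390 nM, and compound 2 `CCN(CC)CCCNC(=O)CCC(=O)OCCCCCCSc1ccc([N+](=O)[O-])c2nonc12`, which in this assay gives 440 nM.

On these two numbers compound 2 cannot be set apart from compound 1: a 1.1-fold higher number from compound 1 to compound 2 (0.05 log units; within the scatter). Compound 3 `O=C(CCC(=O)N1CCCCC1)OCCCCCCSc1ccc([N+](=O)[O-])c2nonc12` differs from compound 2 in one place: piperidin-1-yl in place of (3-(diethylamino)propyl)amino on a carbonyl carbon. Going by the values given here, only one measured step touches the same part of the shared core, namely a 1.1-fold higher number from compound 1 to compound 2 (0.05 log units; within the scatter), where the group on the amide-type nitrogen was exchanged and nothing beyond the scatter followed. Among the compounds with values here, no measured step covers making that nitrogen part of a ring, so the expectation rests on that single step alone. Compound 3 is therefore expected to give 450 nM in this assay, with a range from 180 nM to 1100 nM. The expected step is a 1.0-fold higher number from compound 2 to compound 3 (0.01 log units; within the scatter), not beyond the scatter, with the wider range reflecting the unmeasured ring.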

Compound 3, half-maximal inhibitory concentration: 110 nM
Beside the measured number, compound 3's estimate is 4.1-fold (0.61 log units) above it; measured number outside the range, below it.
By their numbers in this assay, from the lowest: compound 3; then compounds 1 and 2 (each within the scatter of the next).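

The position on the carbonyl carbon, which had looked indifferent to the group it carried, does respond in this assay: piperidin-1-yl in place of (3-(diethylamino)propyl)amino gives a modest step (a 4.0-fold lower number from compound 2 to compound 3 (0.60 log units; beyond the scatter)), and piperidin-1-yl in place of (4-methylphenyl)amino gives another (a 3.5-fold lower number from compound 1 to compound 3 (0.55 log units; beyond the scatter)). The two groups that leave are very different, one an open chain and one carrying an aromatic ring, yet the same entering group moves the number beyond the scatter from both. Nothing available explains these steps.

Compound 3 differs from compounds 1 and 2 both in having this nitrogen inside a ring and in lacking the amide hydrogen, and the compounds shown do not separate the two. A dimethylamino group at this place would bear on that question, while pyrrolidin-1-yl or morpholin-4-yl would test how much the ring itself tolerates change.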